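This account rests on a few compounds, and the source may have more. Where it says the series, first, only, none or still open, it means among the compounds named here.

Measured compounds in a functional assay on SGC-7901 cells (Homo sapiens) for inhibition, read by MTT assay, with a stated time of 48 h; on this read-out higher numbers stand for weaker inhibition and lower numbers for stronger inhibition:

- compound 1 `Cc1nnsc1CO/N=C/c1c(C)nn(C)c1Oc1cccc(F)c1`: > 50000 nM, a limit of the assay
- compound 2 `Cc1nnsc1CO/N=C/c1c(C)nn(C)c1Oc1cccc(C(F)(F)F)c1`: 12400 nM
- compound 3 `Cc1cccc(Oc2c(/C=N/OCc3snnc3C)c(C)nn2C)c1`: 12800 nM

Compound 1 stands only at a limit, with no number of its own (the limit of > 50000 nM in this assay, at which 1 of the 3 values shown sits). The two steps away from it both lower the number: an at least 4.0-fold lower number from compound 1 to compound 2 (0.60 log units; beyond the scatter) and an at least 3.9-fold lower number from compound 1 to compound 3 (0.59 log units; beyond the scatter). Between those two products, a 1.0-fold higher number from compound 2 to compound 3 (0.01 log units; within the scatter), so on the numbers shown the two cannot be ordered.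

Compound 4 `Cc1nnsc1CO/N=C/c1c(C)nn(C)c1Oc1cccc(F)c1F` keeps the fluoro of compound 1 and adds a second one: fluoro in place of hydrogen on an aromatic carbon. For the measured compounds named here, no measured step in the set exchanges hydrogen for fluoro, so none bears directly on this change; the measured steps only show that the number drops when the single fluoro is replaced. With compound 1 at a limit, the direction of the step in this assay is open, and the estimate leans toward the number staying weak, with a sizable chance of another limit. For compound 4 the expected step is an at least 1.2-fold lower number from compound 1 to compound 4 (0.09 log units; that floor lies within the scatter), giving an estimated 40000 nM, in the range 12000 nM to 120000 nM.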

Compound 4, half-maximal inhibitory concentration: 25700 nM
Compound 4: the middle estimate sits 1.6-fold (0.19 log units) above what was measured; the measured number falls inside the stated range.
By their numbers in this assay, from the lowest: compounds 2, 3 and 4 (each within the scatter of the next, the first and the last beyond it). At a limit, above all of these: compound 1.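

In this assay, for the compounds shown here, a second fluoro ortho to a fluoro group gives the first reading of hydrogen exchanged for fluoro on this ring: an at least 1.9-fold lower number from compound 1 to compound 4 (0.28 log units; that floor lies within the scatter). That step stays a floor, since compound 1 has only a limit and no number of its own: the limit of > 50000 nM in this assay, at which 1 of the 4 values shown sits. Compound 4 does give a number of its own with the 2,3-difluorophenyl group, and a 2.0-fold higher number from compound 3 to compound 4 (0.30 log units; within the scatter), so compound 3 and compound 4 cannot be ordered.

Still open, on these data alone, is how far compound 1 truly lies from compound 4, so the size of the fluoro step remains unknown. Also open, as far as these compounds go, are what a chloro, a methoxy or an amine would give at this same place, and whether a fluoro here would read the same alongside the trifluoromethyl of compound 2 or the methyl of compound 3.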